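Swapping the aminophenyl ketone for a difluorophenyl ketone

The source may hold more compounds than are shown below. What is called first, only, known or untested is meant among the compounds shown, and "the series" means these compounds.

Of the compounds shown here, three that share one core have been tested in a functional assay on OVCAR-8 cells (Homo sapiens) for cytotoxicity, read by sulforhodamine B assay, with a stated time of 48 h, tested at 1 uM; on this read-out lower numbers stand for a stronger effect and higher numbers for a weaker effect at the one concentration tested. Compound 1 `COc1cc(-c2cc(/C=C/C(=O)c3ccc(N)cc3)[nH]n2)cc(OC)c1OC` gives 81%. Compound 2 `COc1ccc(-c2cc(/C=C/C(=O)c3ccc(OC)c(OC)c3)[nH]n2)cc1` gives 75%, and compound 3 `COc1ccc(-c2cc(/C=C/C(=O)c3ccc(N)cc3)[nH]n2)cc1OC` gives 93%. On these three numbers compound 1 stands second highest: its gap to compound 2 lies within the scatter, so the two cannot be ordered, while the step of a number 12 percentage points higher from compound 1 to compound 3 (beyond the scatter) lies beyond it.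

Compound 4 `COc1cc(-c2cc(/C=C/C(=O)c3ccc(F)c(F)c3)[nH]n2)cc(OC)c1OC` has not yet been measured in this assay. It differs from compound 1 in one place: 3,4-difluorophenyl in place of 4-aminophenyl on a carbonyl carbon. Among the measured compounds shown here, no measured step bears on this change. For the measured compounds named here, the only single-point step, from compound 1 to compound 3, concerns a methoxy group on the other aromatic ring and says nothing about the ketone side. Compound 2 carries a different group on the ketone side as well, but it also differs elsewhere, so its value of 75% can only show that a ketone aryl without the amino group still gives a number of the same order.

Going by the values given here, with no guiding step, no change beyond the scatter is expected: compound 4 is estimated at 80% in this assay, within 62% to 96%, which means an expected step of a number 1 percentage points lower from compound 1 to compound 4 (within the scatter).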

Compound 4, a percentage reported as activity, at one concentration (the size of the read-out at that concentration, not a potency): 89%
Compound 4: middle estimate off by 9 percentage points, on the low side, within the range that was stated.
By their numbers in this assay, from the lowest: compounds 2, 1, 4 and 3 (each within the scatter of the next, the first and the last beyond it).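

In this assay, among the compounds shown here, this is the first step that isolates the ketone side of the molecule: a number 8 percentage points higher from compound 1 to compound 4 (within the scatter), so the two compounds cannot be ordered. In this one pair, 3,4-difluorophenyl can stand in place of 4-aminophenyl on a carbonyl carbon without a difference that can be told from the scatter, so the amino group is not required for a number of this size, and compound 4, at 89%, gives no sign of a strong effect at the one concentration tested. Nothing available explains why the two groups read so much alike.

The compounds shown leave open whether a phenyl ring carrying a carboxylic acid, a hydroxyl or a dimethylamino group on the same carbonyl carbon would give a number beyond the scatter from that of compound 1. They also leave open whether the same swap would read alike on the core of compound 3, since this single pair cannot show whether the result holds beyond the core of compound 1.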